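Amide Aryl Swap: Methoxyphenyl to Benzothiophene

The source may hold more compounds than are shown below. What is called first, only, known or untested is meant among the compounds shown, and "the series" means these compounds.

Of the compounds shown here, two have been measured so far.

Compound 1 `CN1[C@@H]2c3[nH]c4ccccc4c3C[C@H]1[C@H](C#N)N1[C@@H](CNC(=O)c3ccc(Cl)cc3)c3[nH]c4ccccc4c3C[C@@H]21`: in a functional assay on A2780 cells (Homo sapiens) for cytotoxicity, read by MTT assay, with a stated time of 72 h (a higher number here means a weaker inhibitor, a lower number a stronger inhibitor), compound 1 gives 230 nM.
Compound 2 `COc1ccc(C(=O)NC[C@H]2c3[nH]c4ccccc4c3C[C@H]3[C@H]4c5[nH]c6ccccc6c5C[C@@H]([C@H](C#N)N23)N4C)cc1`: in this assay compound 2 gives 320 nM.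

For the measured compounds named here, these two numbers sit close together; the single step between them, a 1.4-fold higher number from compound 1 to compound 2 (0.14 log units; within the scatter), lies within the usual scatter, so the two compounds cannot be told apart on this assay.

Compound 3 `CN1[C@@H]2c3[nH]c4ccccc4c3C[C@H]1[C@H](C#N)N1[C@@H](CNC(=O)c3cc4ccccc4s3)c3[nH]c4ccccc4c3C[C@@H]21` differs from compound 2 by 1-benzothiophen-2-yl in place of 4-methoxyphenyl on a carbonyl carbon. Going by the values given here, no measured step touches this kind of exchange. Among the compounds with values here, the only step available, a 1.4-fold higher number from compound 1 to compound 2 (0.14 log units; within the scatter), replaced one small group on the distant aromatic ring with another and produced no change beyond the scatter, which gives no hint that the amide aryl group moves the number much. Compound 3 is therefore expected to show a 1.1-fold lower number from compound 2 to compound 3 (0.03 log units; within the scatter). The estimate for compound 3 is 300 nM, with a range from 110 nM to 850 nM.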

Compound 3, half-maximal inhibitory concentration: 20 nM
Compound 3: the middle estimate sits 15-fold (1.18 log units) above what was measured, and the stated range ends above it.
By their numbers in this assay, from the lowest: compound 3; then compounds 1 and 2 (each within the scatter of the next).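

The aryl group on the amide carbonyl carbon is not a silent position: putting 1-benzothiophen-2-yl in place of 4-methoxyphenyl gives a 16-fold lower number from compound 2 to compound 3 (1.20 log units; beyond the scatter) in this assay and, in place of 4-chlorophenyl, gives a 12-fold lower number from compound 1 to compound 3 (1.06 log units; beyond the scatter) in the same test. Since a lower number here means a stronger inhibitor, replacing the whole aryl group achieved what the earlier exchange of one small group on the phenyl ring did not, a shift beyond the scatter. No supporting measurement is available to say why the number falls.

The compounds shown leave open whether the sulfur or the fused second ring matters more, which a thiophene or naphthyl group at this place could help separate. They also leave open how an amine or a carboxylic acid on the benzothiophene ring would read.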